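This account rests on a few compounds, and the source may have more. Where it says the series, first, only, none or still open, it means among the compounds named here.

Compound 2 `CCN(Cc1c(C(F)(F)F)nc2n1CCCN2c1c(C)cc(C)cc1C)CC1CC1` gives 31 nM in an in vitro assay on IMR-32 cells for displacement of a labelled ligand from corticotropin-releasing factor receptor 1 (Homo sapiens) (on this read-out lower numbers stand for stronger inhibition and higher numbers for weaker inhibition), the lowest of the two numbers recorded so far, though compound 1 `CCCN(Cc1c(C(F)(F)F)nc2n1CCCN2c1c(C)cc(C)cc1C)CC1CC1` gives 32 nM in this assay, within the scatter of it. Among the compounds with values here, the single step between them, a 1.0-fold lower number from compound 1 to compound 2 (0.01 log units; within the scatter), exchanges a propyl for an ethyl on the amine and leaves the number essentially where it was. Compound 3 `Cc1cc(C)c(N2CCCn3c2nc(C(F)(F)F)c3CN2CCCCC2)c(C)c1` goes further at the same amine: piperidin-1-yl in place of (cyclopropylmethyl)(ethyl)amino on a saturated chain carbon bound to an aromatic carbon. Within the data shown here, no measured step speaks directly to this exchange of two open substituents for a ring; the step already seen shows only that a small change at this amine is tolerated. A step of a 1.8-fold higher number from compound 2 to compound 3 (0.25 log units; within the scatter) is therefore expected, small and towards a somewhat higher number, with wide uncertainty. Compound 3 is expected to give 55 nM in this assay, within a range of 15 nM to 220 nM.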

Compound 3, inhibition constant: 245 nM
For compound 3 the middle estimate is 4.5-fold (0.65 log units) below the measured one; measured number outside the range, above it.
By their numbers in this assay, from the lowest: compounds 2 and 1 (each within the scatter of the next); then compound 3.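

The amine on the saturated chain carbon bound to an aromatic carbon proves less forgiving than the first step suggested. In this assay, replacing the two open substituents with piperidin-1-yl gives a step beyond the scatter (a 7.9-fold higher number from compound 2 to compound 3 (0.90 log units; beyond the scatter)), and the same holds with propyl as the open chain (a 7.7-fold higher number from compound 1 to compound 3 (0.88 log units; beyond the scatter)), whereas the exchange of propyl for ethyl left the number within the scatter. No evidence at hand accounts for the size of this change.

The three compounds do not separate the loss of the cyclopropylmethyl group from the closing of the ring. Nor do they show whether a pyrrolidine ring, a morpholine ring or an open diethylamino group would stand nearer to compound 2 or to compound 3.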